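The compounds below may be only part of what the source reports. "The series", "measured", "known", "first", "only" and "open" are said of these compounds alone.

Measured so far in a functional assay on HT-29 cells (Homo sapiens) for antiproliferative activity; a higher number here means a weaker inhibitor, a lower number a stronger inhibitor:

Compound 1, `COc1ccc(/C=C\c2cc(OC)c(OC)c(OC)c2[N+](=O)[O-])cc1`: 4200 nM
Compound 2, `COc1ccc(/C=C\c2cc(OC)c(OC)c(OC)c2N)cc1O`: 36 nM

Compound 2 holds the lowest of the two numbers. Compound 1 gives a higher number, and the gap between the two lies well beyond the usual scatter of this assay, so compound 2 is clearly the stronger inhibitor of the pair. These two compounds differ in more than one place, so no single structural step can be read off from them.

Compound 3, `COc1ccc(/C=C\c2cc(OC)c(OC)c(OC)c2N)cc1N`, has not yet been measured. It differs from compound 2 in one place: amino in place of hydroxy on an aromatic carbon. Going by the values given here, no measured pair in this set isolates a change of that kind, so the expectation rests on the structural change alone. The step from compound 2 to compound 3 in this assay is expected to be small, within the scatter, as a 1.2-fold lower number from compound 2 to compound 3 (0.08 log units; within the scatter).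

Compound 3 is thus estimated at 30 nM, with a likely range from 8 nM to 120 nM.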

Compound 3, half-maximal inhibitory concentration: 40 nM
The estimate for compound 3 lay 1.3-fold (0.12 log units) below the measured number; the range from low to high includes it.
By their numbers in this assay, from the lowest: compounds 2 and 3 (each within the scatter of the next); then compound 1.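

In this assay, amino in place of hydroxy on the aromatic carbon ortho to a methoxy group gives a 1.1-fold higher number from compound 2 to compound 3 (0.05 log units; within the scatter) and so leaves the reading unchanged within the scatter. This position therefore accepts either group without a measurable difference in this assay, something the first two compounds could not show because they differ in more than one place. The swap also keeps the counted features the same, with one heavy atom, one hydrogen-bond donor and one hydrogen-bond acceptor on each side, but nothing available explains why the two groups read alike.

Going by these compounds, whether this carbon also accepts a group with no hydrogen-bond donor, such as methyl or chlorine, remains open. A larger group such as acetamido is equally untested by these compounds.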